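A few compounds are considered here, and "the series" means these few. Any claim that something is new, unique, unknown or untested is made for them only; others in the source may bear on it.

Compound 1 `CC(C)N(CCN(C(=O)Nc1ccc(F)c(Cl)c1)C1CC[C@]2(c3cccc(C#N)c3)CC2C1)C(C)C` is the point of departure. For the measured compounds named here, in a functional assay for antagonist activity at melanin-concentrating hormone receptor 1 (Homo sapiens) (on this read-out higher numbers stand for weaker inhibition and lower numbers for stronger inhibition), compound 1 gives 4.98 nM, which places it second highest of the three numbers so far. The closest neighbour is compound 3 `CC(C)N(CCN(C(=O)Nc1cc(Cl)nc(Cl)c1)C1CC[C@]2(c3cccc(C#N)c3)CC2C1)C(C)C`, which gives 2.4 nM in this assay, a change described as a 2.1-fold lower number from compound 1 to compound 3 (0.32 log units; beyond the scatter). Further away stands compound 2 `CC(C)N(CCN(C(=O)Nc1ccc(F)c(Cl)c1)C1CC[C@]2(c3cccc(CN(C)C)c3)CC2C1)C(C)C`, which gives 13 nM, a change described as a 2.6-fold higher number from compound 1 to compound 2 (0.42 log units; beyond the scatter). Both measured steps are modest, and both touch parts of the molecule other than the one altered next.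

Compound 4 `CC(=O)N1CCC(CN(C(=O)Nc2ccc(F)c(Cl)c2)C2CC[C@]3(c4cccc(C#N)c4)CC3C2)CC1` differs from compound 1 in a single place: 1-acetylpiperidin-4-yl in place of (diisopropylamino)methyl on a saturated chain carbon bound to an amide-type nitrogen. Going by the values given here, no measured step changes this part of the shared core, so there is nothing directly comparable to lean on; the two steps seen only show that single alterations elsewhere moved the number modestly in either direction. The step from compound 1 to compound 4 is therefore expected to be small or none beyond the scatter, estimated as a 2.0-fold higher number from compound 1 to compound 4 (0.30 log units; within the scatter). For compound 4 the expected value in this assay is 10 nM, within a range from 2.5 nM to 40 nM.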

Compound 4, inhibition constant: 312 nM
The estimate for compound 4 lay 31-fold (1.49 log units) below the measured number; the whole stated range lies below it.
By their numbers in this assay, from the lowest: compound 3; then compound 1; then compound 2; then compound 4.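

Replacing the 2-(diisopropylamino)ethyl chain with (1-acetylpiperidin-4-yl)methyl gives a 63-fold higher number from compound 1 to compound 4 (1.80 log units; beyond the scatter) in this assay, a large step, whereas the two earlier single changes on other parts of the molecule were modest. This position on the saturated chain is therefore far less forgiving of change than those steps could suggest. The change alters several things at once, since the entering group brings a six-membered ring, an oxygen and a double bond outside aromatic rings, and nothing shown accounts for the size of this step. 

The compounds shown leave open which of these differences matters, or whether the loss of the diisopropylamino group itself is what counts. A 2-(dimethylamino)ethyl chain or a piperidin-4-yl group without the acetyl would help separate these possibilities.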